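The source may report more compounds than this note shows. Statements on the series, on what has been measured and on what is new or still open speak of the compounds shown alone.

Compound 2 `Cc1ccccc1/C=C/C(=O)NNC(=O)c1ccc2c(c1)OCCO2` belongs to a small group of hydrazides that share one core and differ only in the aryl group attached to the double-bonded chain carbon. In an ADME assay on cells (Macrophage) for cytotoxicity, read by MTT assay, with a stated time of 24 h (a lower number here means that less compound is tolerated, a higher number that more compound is tolerated), compound 2 gives 268000 nM. Compound 1 `COc1ccc(/C=C/C(=O)NNC(=O)c2ccc3c(c2)OCCO3)cc1` gives 319000 nM, and compound 3 `O=C(/C=C/c1ccccc1Br)NNC(=O)c1ccc2c(c1)OCCO2` gives 315000 nM. Compound 2 stands at the lowest of these three numbers, yet the step of a 1.2-fold lower number from compound 1 to compound 2 (0.08 log units; within the scatter) and the step of a 1.2-fold higher number from compound 2 to compound 3 (0.07 log units; within the scatter) are both within the scatter, so the three compounds cannot be separated on this measurement.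

Compound 4 `O=C(/C=C/c1cccc(Cl)c1)NNC(=O)c1ccc2c(c1)OCCO2` has not yet been measured in this assay. 3-chlorophenyl in place of 2-methylphenyl on a double-bonded chain carbon bound to a double-bonded chain carbon

For the measured compounds named here, every measured step so far swaps one aryl group for another at this same place: a 1.2-fold lower number from compound 1 to compound 2 (0.08 log units; within the scatter), a 1.0-fold lower number from compound 1 to compound 3 (0.01 log units; within the scatter) and a 1.2-fold higher number from compound 2 to compound 3 (0.07 log units; within the scatter) all stayed within the scatter. No change at this position has moved the tolerated concentration beyond it. Compound 4 is therefore expected to behave the same way, with an estimated step of a 1.1-fold higher number from compound 2 to compound 4 (0.05 log units; within the scatter) that stays within the scatter. The estimate for compound 4 is 300000 nM, with a range from 200000 nM to 450000 nM.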

Compound 4, half-maximal cytotoxic concentration: 391000 nM
The estimate for compound 4 lay 1.3-fold (0.12 log units) below the measured number; measured number inside the range.
By their numbers in this assay, from the lowest: compounds 2, 3, 1 and 4 (each within the scatter of the next).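

In this assay, 3-chlorophenyl behaves like the other aryl groups at this place: a 1.5-fold higher number from compound 2 to compound 4 (0.16 log units; within the scatter), a 1.2-fold higher number from compound 3 to compound 4 (0.09 log units; within the scatter) and a 1.2-fold higher number from compound 1 to compound 4 (0.09 log units; within the scatter). The four compounds now carry 2-methylphenyl, 2-bromophenyl, 3-chlorophenyl and 4-methoxyphenyl, so neither the identity of these groups nor the ring numbering in their names separates the compounds on this measurement, and even the widest step seen so far, the change from 2-methylphenyl to 3-chlorophenyl, stays within the scatter. No supporting measurement is available to explain the small differences that remain.

All four compounds still have a substituted phenyl ring at this place. On these data alone, it remains open whether an amine, a carboxylic acid or a longer chain there would give a step beyond the scatter.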